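Where compound 1 stands and what compound 3 may give

The source may report more compounds than this note shows. Statements on the series, on what has been measured and on what is new or still open speak of the compounds shown alone.

Compound 1, `CC(=O)c1cccc(Nc2ccnc(SCC(=O)c3ccc(-c4ccccc4)cc3)n2)c1`, gives 16% in a functional assay on K562 cells (Homo sapiens) for inhibition, read by sulforhodamine B assay, with a stated time of 48 h, tested at 10 uM; a higher number here means more inhibition of growth at the concentration tested, a lower number less inhibition of growth.
Compound 2, `COc1ccc(C(=O)CSc2nccc(Nc3cccc(C(C)=O)c3)n2)cc1`, gives 37% in this assay.

For the measured compounds named here, compound 1 holds the lowest of the two numbers so far. Going by the values given here, the only measured step is a number 21 percentage points higher from compound 1 to compound 2 (beyond the scatter), and it concerns the group on the aromatic carbon at the far end of the molecule, not the part that is changed next.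

Compound 3, `CC(=O)c1ccc(Nc2ccnc(SCC(=O)c3ccc(-c4ccccc4)cc3)n2)cc1`, differs from compound 1 by 4-acetylphenyl in place of 3-acetylphenyl on a nitrogen on an aromatic ring. Among the compounds with values here, no measured pair bears on this change: the step from compound 1 to compound 2 alters a different position, so its size says nothing about moving the acetyl group. Within the data shown here, with no step in hand that touches the acetylphenyl group, the working expectation is that compound 3 will show no step beyond the usual scatter relative to compound 1, in either direction. The estimate for compound 3 in this assay is therefore 18%, with a range from 5% to 40%. This estimate corresponds to a number 2 percentage points higher from compound 1 to compound 3 (within the scatter), a step that is expected to stay within the scatter.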

Compound 3, percent growth inhibition at one concentration: 10%
Estimate against measurement, compound 3: 8 percentage points above; low and high end bracket the measured number.
By their numbers in this assay, from the lowest: compounds 3 and 1 (each within the scatter of the next); then compound 2.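

Exchanging 3-acetylphenyl for 4-acetylphenyl gives a number 6 percentage points lower from compound 1 to compound 3 (within the scatter) in this assay. For the compounds shown here, this is the first reading at this position, as the earlier pair spoke only to the group at the far end of the molecule, and it shows that, with the phenyl group of compound 1 kept, the two acetyl placements cannot be told apart in this read-out. The measurements shown offer no evidence that would explain this result.

As far as these compounds go, the acetyl move has been read on only one background, so it remains open whether compound 2, with methoxy in place of phenyl, would respond to the same move in the same way. From the compounds shown here alone, it also remains open whether a different group on this ring, such as an amine or a carboxylic acid in place of the acetyl group, would give a step beyond the scatter, and whether a reading at a single concentration captures all that separates compound 1 from compound 3.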